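The source may report more compounds than this note shows. Statements on the series, on what has been measured and on what is new or still open speak of the compounds shown alone.

Measured so far in an ADME assay on TZM cells (Homo sapiens) for cytotoxicity, read by XTT assay, with a stated time of 4 days (a higher number here means that more compound is tolerated, a lower number that less compound is tolerated), are two compounds.
- Compound 1 `Cc1cc(/C=C/C#N)cc(C)c1Oc1cc(Nc2ccc(C#N)cc2)c(N)cc1C(N)=O` gives > 23600 nM as a limit.
- Compound 2 `Cc1cc(/C=C/C#N)cc(C)c1Oc1cc(Nc2ccc(C#N)cc2)c(N)cc1[N+](=O)[O-]` gives > 24400 nM as a limit.

For the measured compounds named here, compound 1 therefore stands only at a limit, and the one further value is also a limit. Compound 3 `Cc1cc(CCC#N)cc(C)c1Oc1cc(Nc2ccc(C#N)cc2)c(N)cc1C(N)=O` carries 2-cyanoethyl in place of 2-cyanoethenyl on an aromatic carbon, as counted here: 2-cyanoethyl in place of 2-cyanoethenyl on an aromatic carbon and nothing else changes. Going by the values given here, the only measured step is a step that the two limits leave unreadable from compound 1 to compound 2 and it concerns a different group, so it gives no size to carry over. No step beyond the scatter is expected in this assay for this change. For compound 3 the expected value is 25000 nM with an estimated range from 11000 nM to 50000 nM and a report as a limit is likely. The expected step is a step that the limit leaves unreadable from compound 1 to compound 3 and it stays within the scatter.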

Compound 3, half-maximal cytotoxic concentration: > 9400 nM
Compound 3 gave a limit, no number (the forecaster's own chance of this, stated with the estimate: 80%); the middle value lies beyond the limit too.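

For the compounds shown here, both compound 1 and compound 3 are reported only as limits in this assay, and no step between them can be read. The compounds shown leave open at what concentration any of them becomes cytotoxic.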